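Sulfanyl substituent change in the vinyl ketone series

A few compounds are considered here, and "the series" means these few. Any claim that something is new, unique, unknown or untested is made for them only; others in the source may bear on it.

Compound 3 `COc1ccc(/C=C(/SCc2ccc(F)cc2)C(=O)c2ccc(Cl)cc2)c(OC)c1OC` is the reference for this step. In a functional assay on DU-145 cells (Homo sapiens) for inhibition, read by trypan blue exclusion, with a stated time of 96 h (on this read-out higher numbers stand for weaker inhibition of growth and lower numbers for stronger inhibition of growth), compound 3 gives 10000 nM. That is the higher of the two numbers in hand: compound 2 `Cc1ccc(S(=O)(=O)/C(=C/c2ccccc2OCc2ccccc2)C(=O)c2ccc(Br)cc2)cc1` gives 1000 nM in this assay, and the gap between them lies beyond the scatter. Compound 1 `O=C(O)c1cc(/C=C(\C(=O)c2c(F)c(F)c(F)c(F)c2F)S(=O)(=O)c2ccc(Br)cc2)ccc1O` returns only a limit of the assay, > 100000 nM. Among the measured compounds shown here, the sole limit among the values is the limit of > 100000 nM in this assay, at which 1 of the 3 values shown sits.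

The step under study goes to compound 4 `COc1ccc(/C=C(/Sc2ccccc2Cl)C(=O)c2ccc(Cl)cc2)c(OC)c1OC`, not yet measured in this assay. The change is 2-chlorophenyl in place of 4-fluorobenzyl on a sulfur. For the measured compounds named here, no measured pair differs in a single place, so the size of this kind of step cannot be read from the numbers in hand, and two numbers with one limit show no pattern for the group on the sulfur.

For compound 4 the expected step is small, within the scatter or slightly toward stronger inhibition of growth, read as a 1.7-fold lower number from compound 3 to compound 4 (0.22 log units; within the scatter). Compound 4 is estimated at 6000 nM, with a range from 1500 nM to 30000 nM.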

Compound 4, concentration for 50% growth inhibition: 10000 nM
Beside the measured number, compound 4's estimate is 1.7-fold (0.22 log units) below it, within the range that was stated.
By their numbers in this assay, from the lowest: compound 2; then compounds 3 and 4 (each within the scatter of the next). At a limit, above all of these: compound 1.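

In this assay, among the compounds shown here, this is the first step that differs in a single place, and it gives a direct reading for the group on the sulfur: no change at the digits printed from compound 3 to compound 4 (within the scatter). With the shared core held constant, 2-chlorophenyl and 4-fluorobenzyl on this sulfur cannot be told apart, even though the exchange replaces a benzyl group with a directly attached aryl ring and moves the halogen from fluorine to chlorine. No measured property in hand bears on this step.

A single pair does not show whether this position is insensitive to substitution in general or whether these two groups merely happen to match. As far as these compounds go, whether an amine, a carboxylic acid or a longer chain such as 2-phenylethyl on the sulfur would shift the growth-inhibition number remains open.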